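Pyridin-4-yl in Place of Dimethylaminophenyl: Expected Clearance

This account rests on a few compounds, and the source may have more. Where it says the series, first, only, none or still open, it means among the compounds named here.

Compound 1, `CCOC(=O)C1=C(C)N/C(=C/c2cc(C)n(-c3ccc(CN(C)C)cc3)c2C)C1=O`, in an ADME assay on microsomes from liver (Mus musculus) for metabolic stability, read by LC-MS, tested at 1 uM (on this read-out lower numbers stand for slow clearance and higher numbers for fast clearance), gives 31 mL.min-1.g-1.
Compound 2, `CCOC(=O)C1=C(C)N/C(=C/c2cc(C)n(-c3ccc(Cl)cc3)c2C)C1=O`, in this assay gives 72 mL.min-1.g-1.
Compound 3, `CCOC(=O)C1=C(C)N/C(=C/c2cc(C)n(-c3ccc(N(C)C)cc3)c2C)C1=O`, in this assay gives 56 mL.min-1.g-1.

All three share one core and differ only in the group on the six-membered ring attached to the aromatic nitrogen. Compound 3 stands close to both companions: a 1.3-fold lower number from compound 2 to compound 3 (0.11 log units; within the scatter) and a 1.8-fold higher number from compound 1 to compound 3 (0.26 log units; within the scatter), so on these numbers it cannot be told apart from either. Among the compounds with values here, the only step beyond the scatter is a 2.3-fold higher number from compound 1 to compound 2 (0.37 log units; beyond the scatter), and even that is modest.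

Compound 4, `CCOC(=O)C1=C(C)N/C(=C/c2cc(C)n(-c3ccncc3)c2C)C1=O`, is not yet measured. The change from compound 3 is pyridin-4-yl in place of 4-(dimethylamino)phenyl on an aromatic nitrogen. Within the data shown here, no measured step swaps the ring itself; the three steps seen only exchange a group sitting on that ring, and together they span a narrow band. Among the measured compounds shown here, there is therefore no direct precedent, only the observation that this position has so far moved this assay little. The expectation for compound 4 is a number near those of the measured set, with a 1.2-fold lower number from compound 3 to compound 4 (0.09 log units; within the scatter) as the estimated step, and a wide band to allow for the untested ring swap. The estimated value for compound 4 is 45 mL.min-1.g-1, between 18 mL.min-1.g-1 and 110 mL.min-1.g-1.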

Compound 4, intrinsic clearance in microsomes: 61 mL.min-1.g-1
Compound 4: the middle estimate sits 1.4-fold (0.13 log units) below what was measured; low and high end bracket the measured number.
By their numbers in this assay, from the lowest: compounds 1, 3, 4 and 2 (each within the scatter of the next, the first and the last beyond it).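

Swapping the ring itself on the aromatic nitrogen, with pyridin-4-yl taking the place of a carbon-only ring that carries a group, still yields no step that can be told apart in this assay: the change gives a 1.1-fold higher number from compound 3 to compound 4 (0.04 log units; within the scatter) as its result. Set against the other two companions, the same kind of swap gives a 1.2-fold lower number from compound 2 to compound 4 (0.07 log units; within the scatter) with 4-chlorophenyl leaving and a 2.0-fold higher number from compound 1 to compound 4 (0.29 log units; within the scatter) with 4-((dimethylamino)methyl)phenyl leaving, so all three new steps lie within the scatter, and among these four compounds a hetero atom in this ring and the loss of the group on it leave the clearance number in the same band as its neighbours. Nothing measured here offers an explanation for this result.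

Still open, from the compounds shown here alone, is whether a carboxylic acid or a morpholine on this ring, or a saturated ring such as piperidin-4-yl on the aromatic nitrogen, would stay inside that band. Also open, going by these compounds, is whether pyridin-3-yl, with its ring nitrogen in another place, would behave as pyridin-4-yl does in this assay here.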